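The compounds below may be only part of what the source reports. "The series", "measured", "known", "first", "only" and "open" are said of these compounds alone.

Measured compounds:
Compound 1 `Cc1ccc2[nH]c(=O)c(CN(Cc3ccc(F)cc3)Cc3ccc(C(C)(C)C)cc3)cc2c1`: > 27000 nM
Compound 2 `Cc1ccc2[nH]c(=O)c(CN(Cc3ccc(N(C)C)cc3)Cc3ccc(C(C)(C)C)cc3)cc2c1`: > 5000 nM

In a toxicity assay on MDCK cells (Canis lupus familiaris) for cytotoxicity, read by crystal violet staining, with a stated time of 48 h (on this read-out lower numbers stand for higher toxicity in this test and higher numbers for lower toxicity in this test), compound 2 gives only a limit of the assay, not a number. The same holds for compound 1, whose result in this assay is also a limit. Going by the values given here, the only step among the measured compounds, a step that the two limits leave unreadable from compound 1 to compound 2, cannot be sized because the limit of > 27000 nM in this assay, at which 1 of the 2 values shown sits, and the limit of > 5000 nM in this assay, at which 1 of the 2 values shown sits, both sit at limits.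

Compound 3 `COc1ccc(C(C)N(Cc2ccc(C(C)(C)C)cc2)Cc2cc3cc(C)ccc3[nH]c2=O)cc1` differs from compound 2 in one place: 1-(4-methoxyphenyl)ethyl in place of 4-(dimethylamino)benzyl on an amine nitrogen. Among the compounds with values here, the one measured step that bears on this change is unreadable, so no direction or size can be taken from it, and no change beyond the usual scatter is expected. The step that the limit leaves unreadable from compound 2 to compound 3 is therefore estimated as essentially flat. Compound 3 is expected to give about 20000 nM in this assay, within a range of 5000 nM to 80000 nM, most likely again reported as a limit.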

Compound 3, half-maximal cytotoxic concentration: > 5000 nM
Compound 3 gave a limit, no number; the forecaster's own chance of this, stated with the estimate: 70%; the middle value does not contradict the limit.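

No new step can be read between compound 3 and compound 1 or compound 2: in this assay, all three results are limits, not numbers. The compounds shown leave open whether changing the groups on the amine nitrogen alters the half-maximal cytotoxic concentration at all.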